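This account rests on a few compounds, and the source may have more. Where it says the series, first, only, none or still open, it means among the compounds named here.

Measured compounds:
- compound 1 `COc1ccc(/C=N/Nc2ncc3c(n2)n(C2CCCC2)c(=O)c(=O)n3C)cc1`: in a functional assay on PC-3 cells (Homo sapiens) for antiproliferative activity, read by MTT assay (on this read-out higher numbers stand for weaker inhibition and lower numbers for stronger inhibition), compound 1 gives 26300 nM
- compound 2 `Cn1c(=O)c(=O)n(C2CCCC2)c2nc(N/N=C/c3ccc(F)cc3F)ncc21`: in this assay compound 2 gives 13200 nM

Compound 2 stands together with compound 1, the two numbers not separable on this read-out: the step of a 2.0-fold lower number from compound 1 to compound 2 (0.30 log units; within the scatter) lies within the scatter. Compound 3 `Cn1c(=O)c(=O)n(C2CCCC2)c2nc(N/N=C/c3ccccc3Cl)ncc21` differs from compound 2 in one place: 2-chlorophenyl in place of 2,4-difluorophenyl on a carbon with a double bond to nitrogen. Among the compounds with values here, the only measured step that bears on this change is the one at the same position, from compound 1 to compound 2, which exchanged one aryl group for another without a difference beyond the scatter. On that basis no step beyond the scatter is expected in this assay from compound 2 to compound 3 either, in no particular direction, and the expected step is a 1.0-fold lower number from compound 2 to compound 3 (0.01 log units; within the scatter). Compound 3 is therefore estimated at 13000 nM, with a range from 5000 nM to 35000 nM.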

Compound 3, half-maximal inhibitory concentration: 16300 nM
For compound 3 the middle estimate is 1.3-fold (0.10 log units) below the measured one; measured number inside the range.
By their numbers in this assay, from the lowest: compounds 2, 3 and 1 (each within the scatter of the next).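

In this assay, 2-chlorophenyl in place of 2,4-difluorophenyl on a carbon with a double bond to nitrogen gives a 1.2-fold higher number from compound 2 to compound 3 (0.09 log units; within the scatter) and 2-chlorophenyl in place of 4-methoxyphenyl gives a 1.6-fold lower number from compound 1 to compound 3 (0.21 log units; within the scatter) so neither exchange separates compound 3 from the other two. Where the earlier pair covered only a fluorine-bearing and a methoxy-bearing phenyl, the position now also holds a chlorine-bearing one, and all three stand together on this read-out. Nothing measured on these compounds accounts for this.

All three compounds carry a substituted phenyl at this place, so the range of groups covered remains narrow. Going by these compounds, whether a phenyl bearing an amine or a carboxylic acid, or a longer chain in place of the ring, would give a step beyond the scatter stays open.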